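Moving the chloro group: compound 2 to compound 3

The source may report more compounds than this note shows. Statements on the series, on what has been measured and on what is new or still open speak of the compounds shown alone.

- compound 1 `NC(=O)c1cc(Br)ccc1NC(=O)/C=C/c1ccccc1` gives 62.4%
- compound 2 `NC(=O)c1cc(Br)ccc1NC(=O)/C=C/c1ccccc1Cl` gives 59%

Both values come from a functional assay on K562 cells (Homo sapiens) for antiproliferative activity, read by trypan blue exclusion, with a stated time of 48 h, tested at 10 uM; on this read-out higher numbers stand for more inhibition of growth at the one concentration tested and lower numbers for less inhibition of growth. In this assay compound 2 gives 59%, which lies within the scatter of compound 1 at 62.4%. The two numbers therefore do not separate these compounds.

The next compound is compound 3 `NC(=O)c1cc(Br)ccc1NC(=O)/C=C/c1cccc(Cl)c1`, not yet measured. The change is 3-chlorophenyl in place of 2-chlorophenyl on a double-bonded chain carbon bound to a double-bonded chain carbon. The two compounds have the same atoms, joined differently.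

Within the data shown here, only one measured step bears on this change, chloro in place of hydrogen on an aromatic carbon, which gave a number 3.4 percentage points lower from compound 1 to compound 2 (within the scatter). That step lies within the scatter. Among the measured compounds shown here, no measured pair compares the 2-chlorophenyl and 3-chlorophenyl groups directly, so the evidence is thin.

On the size of that one step, no change beyond the scatter is expected in this assay, and the expected step is a number 1 percentage points higher from compound 2 to compound 3 (within the scatter). For compound 3 the estimated value is 60%, expected to fall in the range from 47% to 72%.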

Compound 3, percent growth inhibition at one concentration: 25.5%
The estimate for compound 3 lay 34.5 percentage points above the measured number; measured number outside the range, below it.
By their numbers in this assay, from the lowest: compound 3; then compounds 2 and 1 (each within the scatter of the next).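

In this assay, the place of the chloro group counts, which compound 1 and compound 2 alone could not show: with the atoms unchanged, 3-chlorophenyl in place of 2-chlorophenyl gives a number 33.5 percentage points lower from compound 2 to compound 3 (beyond the scatter). Chloro in place of hydrogen therefore has no single size of step in this series, since a number 3.4 percentage points lower from compound 1 to compound 2 (within the scatter) stands against a number 36.9 percentage points lower from compound 1 to compound 3 (beyond the scatter), and the outcome depends on which chlorophenyl group results. No measurement shown here offers an explanation for the lower number of compound 3.

Going by these compounds, it remains open whether the lower number belongs to chloro itself or would also follow a fluoro or methoxy group in its place on the ring of compound 3. On these data alone, it is equally open whether the gap between 2-chlorophenyl and 3-chlorophenyl would persist on a core with hydrogen or a carboxylic acid in place of the bromo group, or would shrink or vanish there.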